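Chloro for Fluoro on Two Related Cores

The compounds below may be only part of what the source reports. "The series", "measured", "known", "first", "only" and "open" are said of these compounds alone.

Compound 1 `O=S(=O)(c1cccc(F)c1)c1cn(C2CCNC2)c2ccc(F)cc12` and compound 3 `O=S(=O)(c1cccc(F)c1)c1cn(C2CCNC2)c2ccc(Cl)cc12` share one core. In an assay on HeLa cells for displacement of a labelled ligand from 5-hydroxytryptamine receptor 6 (Homo sapiens), with a stated time of 2 h (a higher number here means a weaker inhibitor, a lower number a stronger inhibitor), compound 1 gives 9.6 nM, and compound 3 gives 15 nM; the change between them, (chloro in place of fluoro on an aromatic carbon), produced a 1.6-fold higher number from compound 1 to compound 3 (0.19 log units; within the scatter). Compound 2 `O=S(=O)(c1cccc(F)c1)c1cn(C2CCNC2)c2cc(F)ccc12` has the same atoms as compound 1 joined differently, and the difference between the two cores is not broken down here. In this assay compound 2 gives 18 nM, a number within the scatter of those for compound 1 and compound 3. Compound 4 `O=S(=O)(c1cccc(F)c1)c1cn(C2CCNC2)c2cc(Cl)ccc12` has not yet been measured; it arises from compound 2 by chloro in place of fluoro on an aromatic carbon, the same change seen from compound 1 to compound 3. Because a 1.6-fold higher number from compound 1 to compound 3 (0.19 log units; within the scatter) stayed within the scatter, the corresponding step is expected to be a 1.6-fold higher number from compound 2 to compound 4 (0.19 log units; within the scatter), much like the earlier one. Compound 4 is therefore estimated at 28 nM in this assay, with a likely range from 12 nM to 65 nM.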

Compound 4, inhibition constant: 72 nM
Estimate against measurement, compound 4: 2.6-fold (0.41 log units) below; measured number outside the range, above it.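

On the core of compound 2, chloro in place of fluoro gives a 4.0-fold higher number from compound 2 to compound 4 (0.60 log units; beyond the scatter) in this assay, a step that on its own lies beyond the scatter. Set beside the step on the core of compound 1, it cannot be told apart from that earlier step: the same change on two cores in this assay, a 1.6-fold higher number (0.19 log units; within the scatter) from compound 1 to compound 3 and a 4.0-fold higher number (0.60 log units; beyond the scatter) from compound 2 to compound 4, 2.6-fold (0.41 log units) apart, within the scatter of two such steps. This gives no firm sign that the core changes what the swap does, yet with a single pair on each core it does not show that the swap carries over unchanged either.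

The compounds shown leave open how a bromo, a methoxy or a nitrile on this aromatic carbon would read on either core. They also leave open whether any such group would separate the two cores more clearly.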